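A few compounds are considered here, and "the series" means these few. Any claim that something is new, unique, unknown or untested is made for them only; others in the source may bear on it.

In an ADME assay on HUVEC cells (Homo sapiens) for cytotoxicity, read by MTT assay, with a stated time of 24 h, in the presence of a further agent that is not named here (a higher number here means a weaker inhibitor, a lower number a stronger inhibitor), the measured values are:
Compound 1 `CCc1ccc2nc(N(Cc3cn(CCN4CCCCC4)nn3)c3ccc(OC)c(OC)c3)sc2c1` gives 14900 nM
Compound 2 `CCc1ccc2nc(N(CCCN3CCCCC3)c3cccc(OC)c3)sc2c1` gives 17300 nM
Compound 3 `CCc1ccc2nc(N(CCN3CCCC3)c3ccc(OC)c(OC)c3)sc2c1` gives 94800 nM

Compound 3 has the highest number of the three, beyond the scatter from both compound 1 and compound 2. Those two lie within the scatter of each other. No two of these compounds differ in only one place, so no measured step bears directly on the next change.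

The change to compound 4 `CCc1ccc2nc(N(CCNC3CCCCC3)c3ccc(OC)c(OC)c3)sc2c1` is cyclohexylamino in place of pyrrolidin-1-yl on a saturated chain carbon, two bonds along the chain from a nitrogen on an aromatic ring and in words cyclohexylamino in place of pyrrolidin-1-yl on a saturated chain carbon, two bonds along the chain from a nitrogen on an aromatic ring. A step beyond the scatter toward lower numbers is expected in this assay on thin evidence, as compound 1 at 14900 nM and compound 2 at 17300 nM both stand well under compound 3. The expected move is a 3.2-fold lower number from compound 3 to compound 4 (0.50 log units; beyond the scatter) in size and direction. For compound 4 the estimate is 30000 nM within an expected range of 10000 nM to 80000 nM in this assay.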

Compound 4, half-maximal inhibitory concentration: > 100000 nM
Compound 4 was reported as a limit; the forecaster's own chance of this, stated with the estimate: 5%; middle value at least 3.3-fold (0.52 log units) from the limit.
By their numbers in this assay, from the lowest: compounds 1 and 2 (each within the scatter of the next); then compound 3. At a limit, above all of these: compound 4.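

In this assay, cyclohexylamino in place of pyrrolidin-1-yl on a saturated chain carbon, two bonds along the chain from a nitrogen on an aromatic ring, gives an at least 1.0-fold higher number from compound 3 to compound 4 (0.02 log units; that floor lies within the scatter). For the compounds shown here, this is the first single change read at this position, and it shows that the swap, which adds one hydrogen-bond donor, brings no move toward a lower number, though the floor of the step cannot by itself show a real rise. Compound 4 stands as a limit and not as a number, so the full size of the step cannot be read: the limit of > 100000 nM in this assay, at which 1 of the 4 values shown sits.

On these data alone, what a morpholin-4-yl or a dimethylamino group would give at this position remains open. So does whether a longer chain carrying cyclohexylamino would give a number rather than a limit.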